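A few compounds are considered here, and "the series" means these few. Any claim that something is new, unique, unknown or untested is made for them only; others in the source may bear on it.

Measured in a functional assay on DU-145 cells (Homo sapiens) for inhibition, read by trypan blue exclusion, with a stated time of 72 h; on this read-out higher numbers stand for weaker inhibition and lower numbers for stronger inhibition:
- compound 1 `Cn1c(=O)c(S(=O)(=O)c2ccc(Cl)cc2Cl)cc2cnc(Nc3ccc4[nH]ccc4c3)nc21` gives 1000 nM
- compound 2 `Cn1c(=O)c(S(=O)(=O)c2ccc(Cl)cc2)cc2cnc(Nc3ccc4[nH]ccc4c3)nc21` gives 250 nM
- compound 3 `Cn1c(=O)c(S(=O)(=O)Nc2ccc(F)cc2)cc2cnc(Nc3ccc4[nH]ccc4c3)nc21` gives 5000 nM

Compound 3 has the highest of these three numbers and is therefore the weakest inhibitor of the set. Its gaps to the other two are a 5.0-fold higher number from compound 1 to compound 3 (0.70 log units; beyond the scatter) and a 20-fold higher number from compound 2 to compound 3 (1.30 log units; beyond the scatter), both beyond the scatter.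

The next compound, compound 4 `Cn1c(=O)c(S(=O)(=O)Nc2ccc(F)cc2F)cc2cnc(Nc3ccc4[nH]ccc4c3)nc21`, carries fluoro in place of hydrogen on an aromatic carbon , turning the (4-fluorophenyl)amino group into (2,4-difluorophenyl)amino.

For the measured compounds named here, the closest precedent is a 4.0-fold lower number from compound 1 to compound 2 (0.60 log units; beyond the scatter), where one chloro fewer on the aromatic ring went with stronger inhibition. Read in reverse, that step hints that an extra halogen could raise the number. The precedent is imperfect, however. It involves chloro rather than fluoro, and in those two compounds the ring sits directly on the sulfonyl sulfur, not on an amino group. The large gap between compound 2 and compound 3 warns that a trend may not carry across that change.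

In this assay, only a slight upward drift is therefore expected, most likely none beyond the scatter, and the expected change is a 1.2-fold higher number from compound 3 to compound 4 (0.08 log units; within the scatter).

For compound 4 the estimated value is 6000 nM, with an expected range from 2000 nM to 18000 nM.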

Compound 4, half-maximal inhibitory concentration: 5000 nM
Beside the measured number, compound 4's estimate is 1.2-fold (0.08 log units) above it; low and high end bracket the measured number.
By their numbers in this assay, from the lowest: compound 2; then compound 1; then compounds 3 and 4 (each within the scatter of the next).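

In this assay, the added fluoro gives no change at the digits printed from compound 3 to compound 4 (within the scatter), so on this ring, at a carbon ortho to a large group and meta to a fluoro group, this one-atom change leaves no mark that can be read. The gaps to the compounds with a ring directly on the sulfonyl sulfur remain, at a 20-fold higher number from compound 2 to compound 4 (1.30 log units; beyond the scatter) and a 5.0-fold higher number from compound 1 to compound 4 (0.70 log units; beyond the scatter), so swapping the whole group on the sulfur still separates these compounds, while the extra ring fluoro does not. An extra halogen therefore does not go with a higher number in every case: the chloro pair shows a 4.0-fold lower number from compound 1 to compound 2 (0.60 log units; beyond the scatter), and compounds 3 and 4 go against that trend, but nothing available explains the difference between the two pairs.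

The compounds shown leave open whether a larger group at this same ring carbon, such as methoxy or a nitrile, would also leave the number unchanged. They also leave open how much of the gap to compound 2 comes from the amino link itself, which a methylene link in its place could help to separate from the change of ring.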